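The source may hold more compounds than are shown below. What is called first, only, known or untested is meant among the compounds shown, and "the series" means these compounds.

Among the compounds with values here, compound 2 `COc1cccc(Nc2nc(Oc3cccc(NC(=O)C=C(C)C)c3)c3sccc3n2)c1` is one of only two compounds measured so far in a functional assay on HeLa cells (Homo sapiens) for inhibition, read by MTT assay, with a stated time of 72 h (a lower number here means a stronger inhibitor, a higher number a weaker inhibitor), in which compound 2 gives 26100 nM. Within the data shown here, its sole neighbour, compound 1 `COc1ccc(Nc2nc(Oc3cccc(NC(=O)C=C(C)C)c3)c3sccc3n2)cc1`, gives 28800 nM in this assay, and the step of a 1.1-fold lower number from compound 1 to compound 2 (0.04 log units; within the scatter) lies within the scatter, so the two compounds stand together rather than apart. Compound 3 `COc1ccc(Nc2nc(Oc3cccc(NC(=O)C=C(C)C)c3)c3sccc3n2)cn1` differs from compound 2 by 6-methoxypyridin-3-yl in place of 3-methoxyphenyl on a nitrogen on an aromatic ring. Among the measured compounds shown here, no measured step exchanges a carbon-only ring for a ring with a hetero atom at this place; the one step in hand, a 1.1-fold lower number from compound 1 to compound 2 (0.04 log units; within the scatter), only moved the methoxy on the phenyl and produced nothing beyond the scatter. Nothing measured speaks to a ring nitrogen here, so no shift beyond the scatter is expected in either direction. Compound 3 is therefore estimated to give about 26000 nM, with a range of 9000 nM to 75000 nM, which means an expected step of a 1.0-fold lower number from compound 2 to compound 3 (0.00 log units; within the scatter).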

Compound 3, half-maximal inhibitory concentration: > 100000 nM
Compound 3: only a limit was reported; the forecaster's own chance of this, stated with the estimate: 15%; middle value at least 3.8-fold (0.58 log units) away from the limit.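

The number for compound 3 in this assay is only a limit of the assay, not a measured value: the limit of > 100000 nM in this assay, at which 1 of the 3 values shown sits. Even so, this place on a nitrogen on an aromatic ring responds to the ring itself: 6-methoxypyridin-3-yl gives an at least 3.8-fold higher number from compound 2 to compound 3 (0.58 log units; beyond the scatter) and an at least 3.4-fold higher number from compound 1 to compound 3 (0.54 log units; beyond the scatter), whereas moving the methoxy on the carbon-only ring gave only a 1.1-fold lower number from compound 1 to compound 2 (0.04 log units; within the scatter). Exchanging a ring carbon for a ring nitrogen, with the methoxy kept, is thus the first change shown that goes beyond the scatter, towards weaker inhibition, and its full size cannot be read past the limit.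

The compounds shown leave open whether a pyridine ring without the methoxy would behave the same way. They also leave open whether an amine or a fluorine in place of that methoxy would bring the number back down.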